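This account rests on a few compounds, and the source may have more. Where it says the series, first, only, none or still open, it means among the compounds named here.

Measured in a functional assay on Jurkat cells (Homo sapiens); on this read-out higher numbers stand for weaker inhibition and lower numbers for stronger inhibition:
- compound 1 `CC(C)[C@H](NC(=O)COc1cccc2ccccc12)C(=O)N[C@@H](CC(=O)O)C(=O)COc1cccc(C(F)(F)F)c1`: > 100000 nM (a limit)
- compound 2 `CC(C)[C@H](NC(=O)COc1cccc2ccccc12)C(=O)N[C@@H](CC(=O)O)C(=O)COc1ccc(C(N)=O)cc1`: > 100000 nM (a limit)

Compound 2 stands at a limit, > 100000 nM, and has no numerical value. For the measured compounds named here, the only other value shown is also a limit. Going by the values given here, the series so far therefore stands at the limit of > 100000 nM in this assay, at which 2 of the 2 values shown sit.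

The next compound is compound 3 `CC(=O)Nc1cccc(OCC(=O)[C@H](CC(=O)O)NC(=O)[C@@H](NC(=O)COc2cccc3ccccc23)C(C)C)c1`, in which 3-acetamidophenyl takes the place of 4-carbamoylphenyl on an oxygen on a saturated carbon: 3-acetamidophenyl in place of 4-carbamoylphenyl on an oxygen on a saturated carbon. Both groups sit on the same shared core, and the change leaves the core otherwise untouched.

Among the compounds with values here, the only measured step bearing on this change is a step that the two limits leave unreadable from compound 1 to compound 2. That step also alters the aryl group on the same oxygen, but it has no readable size, so it supplies neither a magnitude nor a direction to carry over. No step beyond the scatter is therefore expected in this assay, and the expected step is a number no higher from compound 2 to compound 3 (the limit leaves the size open).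

Compound 3 is estimated at 100000 nM, with an expected range of 30000 nM to 300000 nM, and the assay is expected most likely to report only a limit again.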

Compound 3, half-maximal inhibitory concentration: > 100000 nM
Compound 3 gave a limit, no number; the forecaster's own chance of this, stated with the estimate: 70%; the middle value lies on the limit itself.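

In this assay compound 3 gives > 100000 nM, a limit and not a number. The steps among compound 1, compound 2 and compound 3 cannot be read, as all three sit at one limit: the limit of > 100000 nM in this assay, at which 3 of the 3 values shown sit.

Left open is whether 3-(trifluoromethyl)phenyl, 4-carbamoylphenyl and 3-acetamidophenyl differ at all in this assay, and in which direction.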